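The compounds below may be only part of what the source reports. "The series", "measured", "known", "first", "only" and "open" are said of these compounds alone.

Measured so far in a functional assay on U-87MG ATCC cells for antiproliferative activity against U-87 MG (Homo sapiens), read by MTT assay, with a stated time of 48 h, tested at 5 uM; on this read-out lower numbers stand for a stronger effect and higher numbers for a weaker effect at the one concentration tested:
compound 1, `Cc1nc(-c2ccccc2)sc1C(=O)CSc1nc(-c2ccc(Cl)c(Cl)c2)c(C#N)c(=O)[nH]1`, gives 98.6%;
compound 2, `Cc1nc(-c2ccccc2)sc1C(=O)CSc1nc(-c2ccccc2)c(C#N)c(=O)[nH]1`, gives 92.1%;
compound 3, `COc1ccc(-c2nc(C)c(C(=O)CSc3nc(-c4ccc(Cl)c(Cl)c4)c(C#N)c(=O)[nH]3)s2)cc1`, gives 101%.

Compound 4, `COc1ccc(-c2nc(C)c(C(=O)CSc3nc(-c4ccccc4)c(C#N)c(=O)[nH]3)s2)cc1`, has not been measured. It differs from compound 3 by phenyl in place of 3,4-dichlorophenyl on an aromatic carbon. The same change, made from compound 1 to compound 2, reads (phenyl in place of 3,4-dichlorophenyl on an aromatic carbon), and its step in this assay was a number 6.5 percentage points lower from compound 1 to compound 2 (within the scatter). The two cores differ by methoxy in place of hydrogen on an aromatic carbon, a step of a number 2.4 percentage points higher from compound 1 to compound 3 (within the scatter) in this assay. Since the surroundings of the exchanged group are described in the same words in both pairs, the change is the same, so the step is expected to be small: a number 6 percentage points lower from compound 3 to compound 4 (within the scatter), resting on the earlier step of a number 6.5 percentage points lower from compound 1 to compound 2 (within the scatter) from compound 1. Compound 4 is therefore estimated at 95%, with a likely range from 85% to 104%.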

Compound 4, a percentage reported as activity, at one concentration (the size of the read-out at that concentration, not a potency): 99%
Compound 4: middle estimate off by 4 percentage points, on the low side, and the stated range covers the measured number.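

In this assay, phenyl in place of 3,4-dichlorophenyl gives a number 2 percentage points lower from compound 3 to compound 4 (within the scatter), and this step agrees with the one on the other core: the same change on two cores in this assay, a number 6.5 percentage points lower (within the scatter) from compound 1 to compound 2 and a number 2 percentage points lower (within the scatter) from compound 3 to compound 4, 4.5 percentage points apart, within the scatter of two such steps. Methoxy in place of hydrogen gives a number 6.9 percentage points higher from compound 2 to compound 4 (within the scatter), and it agrees in the same way: the same change on two cores in this assay, a number 2.4 percentage points higher (within the scatter) from compound 1 to compound 3 and a number 6.9 percentage points higher (within the scatter) from compound 2 to compound 4, 4.5 percentage points apart, within the scatter of two such steps. Among these compounds, both changes therefore carry between these two cores without a visible difference, but every step here lies within the scatter, so this shows only that neither change can be told apart from noise, not that either has a real effect that transfers.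

Going by these compounds, it remains open whether an amine or a carboxylic acid in place of the phenyl, or a longer chain in place of the methoxy, would give a number clearly apart from these.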